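Methyl to ethyl on the shared core

The source may report more compounds than this note shows. Statements on the series, on what has been measured and on what is new or still open speak of the compounds shown alone.

compound 1 `Oc1nnc(-c2cccnc2)c2ccccc12`: 10200 nM
compound 2 `Cn1nc(-c2cccnc2)c2ccccc2c1=O`: 11500 nM

Going by the values given here, both numbers come from a functional assay (trachea) with Cavia porcellus as the target (on this read-out lower numbers stand for stronger inhibition and higher numbers for weaker inhibition), and are the only measurements so far. In this assay compound 2 stands at 11500 nM and lies within the scatter of compound 1 at 10200 nM in repeated measurements, so the two cannot be ranked.

The next compound to be tested is compound 3 `CCn1nc(-c2cccnc2)c2ccccc2c1=O` with its ethyl where compound 2 has its methyl. The change is methyl in place of hydrogen on a saturated chain carbon bound to an aromatic nitrogen and nothing else in the structure differs.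

Among the compounds with values here, no measured pair differs in one place only, so this assay offers no direct precedent for the size of this change. A small step is expected, with at most a slight lean toward a lower number and nothing clearly beyond the scatter. The estimate amounts to a 1.3-fold lower number from compound 2 to compound 3 (0.11 log units; within the scatter) as the expected step. For compound 3 the expected value is 9000 nM in this assay with an estimated range from 3500 nM to 24000 nM as its likely span.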

Compound 3, half-maximal inhibitory concentration: 1320 nM
Compound 3: the middle estimate sits 6.8-fold (0.83 log units) above what was measured; the measured number lies below the stated range.
By their numbers in this assay, from the lowest: compound 3; then compounds 1 and 2 (each within the scatter of the next).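

At the saturated chain carbon bound to an aromatic nitrogen, the change from methyl to ethyl gives an 8.7-fold lower number from compound 2 to compound 3 (0.94 log units; beyond the scatter) in this assay, so this position responds clearly to the addition of 1 heavy atom (1 carbon), with no ring, hydrogen-bond donor, hydrogen-bond acceptor or net charge entering. Going by these compounds alone, until compound 3, the series held no pair differing in one place only, so this is the first indication that the number can be moved from this position, although it rests on a single pair and the step is graded modest. Nothing available on these compounds accounts for the size of the step.

Going by these compounds, whether the number keeps falling with a longer chain such as propyl or butyl, or whether ethyl is already the end of the effect, stays open, as does the response to a branched isopropyl group or to a chain ending in an amine or a carboxylic acid. Within the data shown here, with only one step at hand, it is also open whether the same methyl to ethyl change would give a step of similar size on a different core.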